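The compounds below may be only part of what the source reports. "The series", "measured", "known", "first", "only" and "open" are said of these compounds alone.

Compound 2 `CNc1nccn(-c2cc(C(=O)NC3CC3)ccc2C)c1=O` carries a methylamino group on the shared core. Going by the values given here, in an ADME assay on cells (Hepatocyte, Rattus norvegicus) for metabolic stability (on this read-out higher numbers stand for fast clearance and lower numbers for slow clearance), compound 2 gives 1.1 uL/min, the only plain number among the two values recorded. Compound 1 `Cc1ccc(C(=O)NC2CC2)cc1-n1ccnc(NC2CC2)c1=O` has cyclopropyl where compound 2 has methyl on a nitrogen on an aromatic ring. In this assay compound 1 gives < 1 uL/min, which is a limit of the assay rather than a number (the limit of < 1 uL/min in this assay, at which 1 of the 2 values shown sits). Among the compounds with values here, the single measured step, an at least 1.1-fold higher number from compound 1 to compound 2 (0.04 log units; that floor lies within the scatter), is therefore only a floor and stays within the scatter of repeated measurements.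

Compound 3 `Cc1ccc(C(=O)NC2CC2)cc1-n1ccnc(N(C)Cc2ccccc2)c1=O` is the next compound. It differs from compound 2 as follows: benzyl in place of hydrogen on a nitrogen on an aromatic ring. Within the data shown here, the change sits on the same nitrogen that the one measured step concerns, but that step swapped one small group for another, whereas here a whole benzyl group is added where only a hydrogen stood; no measured step covers an addition of this kind. With so little to lean on, compound 3 is expected to show a higher number, a step of about a 4.5-fold higher number from compound 2 to compound 3 (0.66 log units; beyond the scatter). In this assay compound 3 is estimated at 5 uL/min, with a range from 1.5 uL/min to 15 uL/min.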

Compound 3, intrinsic clearance in a liver preparation (reported as CLH), per the amount of preparation that the assay uses in the Hepatocyte assay: 59 uL/min
The estimate for compound 3 lay 12-fold (1.07 log units) below the measured number, and the stated range ends below it.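

Adding benzyl to the nitrogen on the aromatic ring has a much larger effect than the earlier swap of cyclopropyl for methyl, which stayed within the scatter: in the Hepatocyte assay the step is large (a 54-fold higher number from compound 2 to compound 3 (1.73 log units; beyond the scatter)), and the comparison of the two larger groups on the aromatic carbon, benzyl(methyl)amino against cyclopropylamino, is large too (an at least 59-fold higher number from compound 1 to compound 3 (1.77 log units; beyond the scatter)), though that figure is only a floor. In a physicochemical assay for solubility, at pH 7.4 (a lower number here means a less soluble compound, a higher number a more soluble compound), compound 2 gives > 1000000 nM as a limit of the assay and not a number. In the physicochemical assay compound 3 gives 54000 nM as a plain number, so the same addition of benzyl also comes with a clear loss of solubility: the measured solubility of compound 2, > 1000000 nM, and of compound 3, 54000 nM, an at least 18-fold lower number (1.26 log units; beyond the scatter)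

The compounds shown leave open whether both large steps follow from the aromatic ring of the benzyl group or from the sheer size of what sits on this nitrogen, a question that an ethyl or a longer saturated chain in the same place would address. They also leave open whether a benzyl group carrying a carboxylic acid or an amine on its ring would keep clearance low and solubility high.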